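Pyrrolopyrimidine series: ring-attachment change at the aromatic nitrogen

A few compounds are considered here, and "the series" means these few. Any claim that something is new, unique, unknown or untested is made for them only; others in the source may bear on it.

Working notes. The measured set is small. Compound 1 `Nc1ncnc2c1c(-c1ccc(Oc3ccccc3)cc1)cn2C[C@H]1CCCN1C(CO)CO` in a functional assay on Ramos cells (Homo sapiens) for antiproliferative activity (on this read-out higher numbers stand for weaker inhibition and lower numbers for stronger inhibition), gives 15300 nM. Compound 3 `Nc1ncnc2c1c(-c1ccc(Oc3ccccc3)cc1)cn2C[C@H]1CCCN1C[C@@H](O)CO` in this assay gives 13500 nM; the step of a 1.1-fold lower number from compound 1 to compound 3 (0.05 log units; within the scatter) is within the scatter, so compound 3 and compound 1 sit at the same level and neither can be ranked above the other. For the measured compounds named here, compound 2 `Nc1ncnc2c1c(-c1cnc3[nH]ccc3c1)cn2C[C@H]1CCCN1C[C@@H]1CO1` is the only further member; for compound 2 the read-out in this assay is "not determined" (no result reported), so it adds no number.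

Compound 4 `Nc1ncnc2c1c(-c1ccc(Oc3ccccc3)cc1)cn2[C@H]1CCN(C[C@@H]2CO2)C1` is the next entry. The change from compound 3 is 1-((oxiran-2-yl)methyl)pyrrolidin-3-yl in place of (1-(2,3-dihydroxypropyl)pyrrolidin-2-yl)methyl on an aromatic nitrogen. Going by the values given here, the sole measured step, a 1.1-fold lower number from compound 1 to compound 3 (0.05 log units; within the scatter), concerns only the group on the amine nitrogen in the ring and was flat; nothing measured touches the attachment at the aromatic nitrogen or the oxirane, and compound 2, the one analogue carrying an oxiranylmethyl group, has no number. The expectation for compound 4 therefore rests on the flat behaviour of this part of the set, with wide uncertainty: a step of a 1.4-fold lower number from compound 3 to compound 4 (0.13 log units; within the scatter) is expected, amounting to no change beyond the scatter. Compound 4 is estimated at 10000 nM, within 2000 nM to 50000 nM.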

Compound 4, half-maximal inhibitory concentration: 6710 nM
Beside the measured number, compound 4's estimate is 1.5-fold (0.17 log units) above it; low and high end bracket the measured number.
By their numbers in this assay, from the lowest: compounds 4, 3 and 1 (each within the scatter of the next, the first and the last beyond it).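

For the compounds shown here, the exchange of the (1-(2-hydroxy-1-(hydroxymethyl)ethyl)pyrrolidin-2-yl)methyl group for 1-((oxiran-2-yl)methyl)pyrrolidin-3-yl on the aromatic nitrogen gives the first step in the set to clear the scatter in this assay, with a 2.3-fold lower number from compound 1 to compound 4 (0.36 log units; beyond the scatter), though the size is modest. Against the 2,3-dihydroxypropyl partner the same kind of exchange gives a 2.0-fold lower number from compound 3 to compound 4 (0.30 log units; within the scatter), so the position accepts a group with a different ring attachment and an oxirane, and no loss appears in either comparison, but only one of the two comparisons separates the compounds. No independent data bear on what lies behind these steps.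

Going by these compounds, each exchange alters the attachment at the aromatic nitrogen and the group on the amine nitrogen in the ring together, so it stays open which of the two carries the step; a 1-(2,3-dihydroxypropyl)pyrrolidin-3-yl group on the aromatic nitrogen would separate them. Also open, on these data alone, is how a simple methyl, a carboxylic acid or a longer chain on that amine nitrogen would read in this assay with the attachment of compound 4 held fixed.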